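Swapping Bromo for Isopropoxy on the Benzyl Ring

The source may hold more compounds than are shown below. What is called first, only, known or untested is meant among the compounds shown, and "the series" means these compounds.

Compound 1, `O=C(CCCC1CCN(Cc2ccccc2)CC1)c1ncco1`: 315 nM
Compound 2, `O=C(CCCC1CCN(Cc2ccc(Cl)cc2)CC1)c1ncco1`: 66 nM
Compound 3, `O=C(CCCC1CCN(Cc2ccc(Br)cc2)CC1)c1ncco1`: 45 nM

All three share one core and differ only at a single aromatic carbon. Going by the values given here, in an assay on isolated protein for inhibition of Fatty-acid amide hydrolase 1 (Homo sapiens) (a higher number here means a weaker inhibitor, a lower number a stronger inhibitor), compound 3 gives the lowest of the three numbers, yet the step of a 1.5-fold lower number from compound 2 to compound 3 (0.17 log units; within the scatter) is within the scatter, so compound 2 and compound 3 cannot be ranked; only the step of a 7.0-fold lower number from compound 1 to compound 3 (0.85 log units; beyond the scatter) sets compound 3 clearly apart.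

Compound 4, `CC(C)Oc1ccc(CN2CCC(CCCC(=O)c3ncco3)CC2)cc1`, is the next step: isopropoxy in place of bromo on an aromatic carbon. Among the compounds with values here, the steps that bear on it are a 4.8-fold lower number from compound 1 to compound 2 (0.68 log units; beyond the scatter) and a 7.0-fold lower number from compound 1 to compound 3 (0.85 log units; beyond the scatter), both modest, both toward lower numbers when a group replaces hydrogen at this carbon. Within the data shown here, no measured step exchanges one such group for a non-halogen, so the direction is uncertain; the expected step is a 1.3-fold higher number from compound 3 to compound 4 (0.12 log units; within the scatter). Compound 4 is therefore estimated at 60 nM, within a range from 20 nM to 250 nM.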

Compound 4, half-maximal inhibitory concentration: 14 nM
The estimate for compound 4 lay 4.3-fold (0.63 log units) above the measured number; the whole stated range lies above it.
By their numbers in this assay, from the lowest: compound 4; then compounds 3 and 2 (each within the scatter of the next); then compound 1.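

In this assay isopropoxy gives a 3.2-fold lower number from compound 3 to compound 4 (0.51 log units; beyond the scatter) and a 4.7-fold lower number from compound 2 to compound 4 (0.67 log units; beyond the scatter) so this carbon accepts a group other than a halogen, and the number falls further than with chloro or bromo. Against plain hydrogen the change is a 23-fold lower number from compound 1 to compound 4 (1.35 log units; beyond the scatter) and it is the only large step among these compounds.

The compounds shown leave open whether the oxygen or the branched carbons carry this gain, which a methoxy or a plain isopropyl group at this carbon would help to separate. Nothing measured alongside these numbers gives a reason for the gain.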